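The compounds below may be only part of what the source reports. "The series", "measured", "known", "first", "only" and "open" are said of these compounds alone.

Measured so far in the series:
- compound 1, `C=C(C)CNC(=S)Nc1cccc(C(F)(F)F)c1`: 43000 nM
- compound 2, `CCOC(=O)c1ccc(NC(=S)Nc2cccc(C(F)(F)F)c2)cc1`: 23000 nM

In an ADME assay on MT4 cells (Homo sapiens) for cytotoxicity (a lower number here means that less compound is tolerated, a higher number that more compound is tolerated), compound 1 gives 43000 nM, which puts it at the upper end of the two numbers recorded, while compound 2 gives 23000 nM. The gap between them lies within the scatter of repeated measurements, so the two compounds are not distinguished by this assay and no order between them is claimed.

Compound 3, `Fc1cccc(NC(=S)Nc2cccc(C(F)(F)F)c2)c1`, is the next compound to be measured. Relative to compound 1 the change is 3-fluorophenyl in place of 2-methylprop-2-en-1-yl on an amide-type nitrogen. Within the data shown here, no pair of measured compounds differs by this single change, so there is no step in this assay against which it can be calibrated; the only guidance is that compound 2, which also places a ring on that nitrogen, sits within the scatter of compound 1.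

On that basis the step from compound 1 to compound 3 is expected to be small, a 1.6-fold lower number from compound 1 to compound 3 (0.20 log units; within the scatter), if anything towards a somewhat lower number, and not clearly beyond the scatter. Compound 3 is therefore estimated at 27000 nM in this assay, with a range from 11000 nM to 65000 nM.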

Compound 3, half-maximal cytotoxic concentration: 20000 nM
For compound 3 the middle estimate is 1.4-fold (0.13 log units) above the measured one; low and high end bracket the measured number.
By their numbers in this assay, from the lowest: compounds 3, 2 and 1 (each within the scatter of the next, the first and the last beyond it).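

In this assay, among these compounds, the change to 3-fluorophenyl in place of 2-methylprop-2-en-1-yl on the amide-type nitrogen gives a 2.2-fold lower number from compound 1 to compound 3 (0.33 log units; beyond the scatter) and is the first step that can be read at this position. It shows that a change at this nitrogen can shift the number beyond the scatter, which the printed values of compound 1 and compound 2 did not show, since those two lie within the scatter of each other. The shift remains modest, however, and compound 3 still lies within the scatter of compound 2, so the replacement of the open chain by an aromatic ring carrying fluorine marks a small move rather than a sharp break, and nothing at hand bears on what lies behind it.

Still open, on these data alone, is whether the step belongs to the aromatic ring itself or to its fluorine, a question that a plain phenyl on the same nitrogen would address. Also open, as far as these compounds go, is how a primary amine, a carboxylic acid or a longer alkyl chain at this nitrogen would read in this assay against compound 1.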